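Swapping the Hydroxyethyl Amide for a Sulfonyl Piperazine

This account rests on a few compounds, and the source may have more. Where it says the series, first, only, none or still open, it means among the compounds named here.

Of the compounds shown here, three sharing one core have been measured in an assay on HEK293 cells for displacement of a labelled ligand from NPC1-like intracellular cholesterol transporter 1 (Homo sapiens); a lower number here means a stronger inhibitor, a higher number a weaker inhibitor. Compound 1 `CC(C)(C)c1ccc(C(=O)N2CCC3(CC2)C(=O)N(CC(=O)NCCO)CN3c2ccccc2)cc1` gives 1000 nM. Compound 2 `CC(C)(C)OC(=O)NCCNC(=O)CN1CN(c2ccccc2)C2(CCN(C(=O)c3ccc(C(C)(C)C)cc3)CC2)C1=O` gives 10900 nM, and compound 3 `O=C(CN1CN(c2ccccc2)C2(CCN(C(=O)c3ccc(C4CCCCC4)cc3)CC2)C1=O)NCCO` gives 2000 nM. Among these three numbers compound 3 stands second highest: the step of a 2.0-fold higher number from compound 1 to compound 3 (0.30 log units; within the scatter) lies within the scatter, whereas compound 2 sits clearly above both of them.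

Compound 4 `CS(=O)(=O)N1CCN(C(=O)CN2CN(c3ccccc3)C3(CCN(C(=O)c4ccc(C5CCCCC5)cc4)CC3)C2=O)CC1` is the next compound and has not yet been measured. It differs from compound 3 in one place: 4-(methylsulfonyl)piperazin-1-yl in place of (2-hydroxyethyl)amino on a carbonyl carbon. The part that leaves carries the hydroxy group and the amide hydrogen; the part that enters is a ring joined to the carbonyl carbon.

Among the compounds with values here, only one measured step touches the same end of the molecule. The step of an 11-fold higher number from compound 1 to compound 2 (1.04 log units; beyond the scatter) shows that replacing the hydroxy on that chain with (tert-butoxycarbonyl)amino weakened binding considerably. Within the data shown here, the present change removes the whole chain and puts a ring in its place, so a higher number is expected for compound 4, although the single comparable step cannot say how far. The estimated step is a 4.0-fold higher number from compound 3 to compound 4 (0.60 log units; beyond the scatter). For compound 4 the estimated value in this assay is 8000 nM, with a likely range from 2500 nM to 25000 nM.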

Compound 4, half-maximal inhibitory concentration: 6300 nM
The estimate for compound 4 lay 1.3-fold (0.10 log units) above the measured number; the range from low to high includes it.
By their numbers in this assay, from the lowest: compounds 1 and 3 (each within the scatter of the next); then compounds 4 and 2 (each within the scatter of the next).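

The swap at this carbonyl carbon gives a 3.2-fold higher number from compound 3 to compound 4 (0.50 log units; beyond the scatter) in this assay. Compound 2 kept the amide hydrogen and altered only the far end of the chain, whereas compound 4 removes the whole (2-hydroxyethyl)amino group, with its 2 hydrogen-bond donors, and puts a ring with 0 hydrogen-bond donors on the carbonyl carbon, and binding is only modestly weaker. So the chain and its hydrogen-bond donors are not essential for a measurable number here, although both changes shown at this end of the molecule raise the number, and neither compound 2 nor compound 4 goes against that; no measurement offered here explains the rise.

From the compounds shown here alone, because the ring, the methylsulfonyl group and the loss of the amide hydrogen all arrive in one step, their separate contributions remain unknown. A morpholine ring or an unsubstituted piperazine on the same carbonyl carbon would help separate them, and a chain ending in a carboxylic acid would show whether any group at this position can lower the number.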